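What Naphthalen-1-yl on Sulfur Might Do for Compound 4

The source may hold more compounds than are shown below. What is called first, only, known or untested is meant among the compounds shown, and "the series" means these compounds.

For the measured compounds named here, in a functional assay on A549 cells (Homo sapiens) for inhibition, read by CCK-8 assay, with a stated time of 72 h, tested at 8 uM (on this read-out higher numbers stand for more inhibition of growth at the one concentration tested and lower numbers for less inhibition of growth), compound 2 `Nc1ccccc1NC(=O)/C=C/c1ccc(CSc2ccc(C(F)(F)F)cn2)cc1` gives 56.5%, the lowest of the three numbers measured so far. Compound 1 `COc1ccc(SCc2ccc(/C=C/C(=O)Nc3ccccc3N)cc2)cc1OC` gives 80.6%, and in a separate measurement compound 3 `Cc1ccc(SCc2ccc(C(=O)Nc3ccccc3N)cc2)cc1` gives 78.3%. Both lie beyond the usual scatter from compound 2.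

Compound 4 `Nc1ccccc1NC(=O)/C=C/c1ccc(CSc2cccc3ccccc23)cc1` has not been measured. It differs from compound 2 in one place: naphthalen-1-yl in place of 5-(trifluoromethyl)pyridin-2-yl on a sulfur. Going by the values given here, only one measured step changes the same place, a number 24.1 percentage points lower from compound 1 to compound 2 (beyond the scatter), where 5-(trifluoromethyl)pyridin-2-yl replaces 3,4-dimethoxyphenyl on a sulfur. That step is modest but beyond the scatter, and the group that lowered the number there is the one leaving now. Compound 3 differs from compound 2 in more than one place, so it offers only loose guidance. Among the compounds with values here, no measured compound carries naphthalen-1-yl, which leaves the outcome uncertain.

A modest rise is therefore expected, smaller than the step at that same place: a number 15.5 percentage points higher from compound 2 to compound 4 (beyond the scatter). Compound 4 is estimated at 72%, with an expected range from 52% to 90%.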

Compound 4, percent growth inhibition at one concentration: 71.2%
Estimate against measurement, compound 4: 0.8 percentage points above; the range from low to high includes it.
By their numbers in this assay, from the lowest: compound 2; then compounds 4, 3 and 1 (each within the scatter of the next).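

In this assay, naphthalen-1-yl in place of 5-(trifluoromethyl)pyridin-2-yl on the sulfur gives a number 14.7 percentage points higher from compound 2 to compound 4 (beyond the scatter), while naphthalen-1-yl in place of 3,4-dimethoxyphenyl gives a number 9.4 percentage points lower from compound 1 to compound 4 (within the scatter). Among these three groups, then, only 5-(trifluoromethyl)pyridin-2-yl stands apart, and two different groups at this position give numbers within the scatter of each other. The groups exchanged between compound 2 and compound 4 both have 10 heavy atoms, so that count does not separate them, and no measurement shown here explains the difference.

Going by these compounds, the ring nitrogen and the trifluoromethyl group leave together, so it remains open which of them goes with the lower number. A plain pyridin-2-yl and a trifluoromethylphenyl on the sulfur would separate the two.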